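This account rests on a few compounds, and the source may have more. Where it says the series, first, only, none or still open, it means among the compounds named here.

Series notes. Compound 1 `COc1cc2cc(Oc3ccc(NC(=O)Nc4ccccc4)cc3)c(C)nc2cc1OC` gives in a functional assay on OVCAR-4 cells (Homo sapiens) for inhibition, read by sulforhodamine B assay, with a stated time of 48 h, tested at 10 uM (on this read-out higher numbers stand for a weaker effect at the one concentration tested and lower numbers for a stronger effect), 70.2%. Compound 2 `COc1cc2cc(Oc3ccc(NC(=O)Nc4ccc(C(F)(F)F)cc4)cc3)c(C)nc2cc1OC` gives in this assay 49%, the lowest of the two numbers shown; the step of a number 21.2 percentage points lower from compound 1 to compound 2 (beyond the scatter) is the only measured one. Compound 3 `COc1cc2cc(Oc3ccc(NC(=O)Nc4cccc(C(F)(F)F)c4)cc3)c(C)nc2cc1OC` differs from compound 2 by 3-(trifluoromethyl)phenyl in place of 4-(trifluoromethyl)phenyl on an amide-type nitrogen. Going by the values given here, no measured step bears on this change: the one known step concerns trifluoromethyl in place of hydrogen, not a move of the group within the ring. Compound 3 is therefore expected near compound 2, with a step of a number 4 percentage points higher from compound 2 to compound 3 (within the scatter) in this assay not beyond the scatter. The estimate for compound 3 in this assay is 53%, between 35% and 71%.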

Compound 3, a percentage reported as activity, at one concentration (the size of the read-out at that concentration, not a potency): 31.7%
The estimate for compound 3 lay 21.3 percentage points above the measured number, and the stated range ends above it.
By their numbers in this assay, from the lowest: compound 3; then compound 2; then compound 1.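

In this assay, the position of the trifluoromethyl group on the ring counts: 3-(trifluoromethyl)phenyl in place of 4-(trifluoromethyl)phenyl on the amide-type nitrogen gives a number 17.3 percentage points lower from compound 2 to compound 3 (beyond the scatter), with the same atoms joined differently. Trifluoromethyl in place of hydrogen now gives a number 38.5 percentage points lower from compound 1 to compound 3 (beyond the scatter), leaving compound 3 with the strongest effect of the three at the one concentration tested. Nothing at hand explains why the two placements differ. Going by these compounds, whether 3-chlorophenyl or 3-methoxyphenyl on the same nitrogen would match 3-(trifluoromethyl)phenyl stays open. A single-concentration read-out also shows the effect of compound 3 at that concentration only.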